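Chain extension from compound 3 to compound 4

The compounds below may be only part of what the source reports. "The series", "measured", "known", "first", "only" and "open" are said of these compounds alone.

Compound 1 `CCCCCCCCCCCCCC[C@@H](O)[C@@H](O)[C@H](CO)n1cc(CCC)nn1` gives 14900 nM
Compound 2 `CCCCCCCCCCCCCC[C@@H](O)[C@@H](O)[C@H](CO)n1cc(CCCC)nn1` gives 14500 nM
Compound 3 `CCCCCCCCCCCCCC[C@@H](O)[C@@H](O)[C@H](CO)n1cc(CCCCCC)nn1` gives 12600 nM

In a functional assay on K562 cells (Homo sapiens) for cytotoxicity, read by MTT assay (a lower number here means that less compound is needed, a higher number that more compound is needed for the effect), compound 3 stands together with compound 1 and compound 2, and no value of the three can be separated from the others. Compound 4 `CCCCCCCCCCCCCC[C@@H](O)[C@@H](O)[C@H](CO)n1cc(CCCCCCCCCCCCC)nn1` keeps the shared core and differs only in the chain. The change is heptyl in place of hydrogen on a saturated chain carbon, six bonds along the chain from an aromatic carbon with heptyl in place of hydrogen on a saturated chain carbon, six bonds along the chain from an aromatic carbon.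

Three measured chain extensions bear on this: a 1.0-fold lower number from compound 1 to compound 2 (0.01 log units; within the scatter) with methyl entering, a 1.2-fold lower number from compound 2 to compound 3 (0.06 log units; within the scatter) with ethyl entering, and a 1.2-fold lower number from compound 1 to compound 3 (0.07 log units; within the scatter) with propyl entering. All of them stay within the scatter. Heptyl is a larger addition than any of these, and no measured chain reaches the length in compound 4, so the extrapolation is loose and the range is kept wide.

With compound 3 at 12600 nM as the anchor, no step beyond the scatter is expected in this assay and neither direction is favoured. The expected step is a 1.0-fold higher number from compound 3 to compound 4 (0.01 log units; within the scatter) as an estimate. Compound 4 is expected at 13000 nM with an estimated range from 6000 nM to 30000 nM for repeated measurements.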

Compound 4, half-maximal effective concentration: > 50000 nM
Compound 4: only a limit was reported; the forecaster's own chance of this, stated with the estimate: 15%; middle value at least 3.8-fold (0.58 log units) away from the limit.
By their numbers in this assay, from the lowest: compounds 3, 2 and 1 (each within the scatter of the next). At a limit, above all of these: compound 4.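

In this assay, this position is no longer silent: the shorter chains on the shared core stayed within the scatter of one another, whereas heptyl in place of hydrogen on a saturated chain carbon, six bonds along the chain from an aromatic carbon, gives an at least 3.9-fold higher number from compound 3 to compound 4 (0.59 log units; beyond the scatter). The comparisons with the two shortest chains point the same way, with an at least 3.4-fold higher number from compound 2 to compound 4 (0.53 log units; beyond the scatter) and an at least 3.3-fold higher number from compound 1 to compound 4 (0.52 log units; beyond the scatter), so the flat reading of compounds 1, 2 and 3 does not carry over to the chain of compound 4. Compound 4 has only a limit of the assay, not a number, so each of these steps is bounded from one side only and its full size stays unknown: the limit of > 50000 nM in this assay, at which 1 of the 4 values shown sits.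

Open is the chain length at which the number starts to rise, since no chain shown is longer than that of compound 3 and shorter than that of compound 4. Also open, as far as these compounds go, is whether an amine or a carboxylic acid in place of heptyl, on the same saturated chain carbon, would keep the number close to that of compound 3.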